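Replacing the 4-methoxyphenyl group of compound 3

The source may hold more compounds than are shown below. What is called first, only, known or untested is meant among the compounds shown, and "the series" means these compounds.

Of the compounds shown here, three sharing one core have been measured so far in a functional assay on HeLa cells (Homo sapiens) for inhibition, read by sulforhodamine B assay; on this read-out lower numbers stand for stronger inhibition and higher numbers for weaker inhibition. Compound 1 `CCc1ccc(NC2=CC(=O)c3nc4n(c3C2=O)[C@H]2OC[C@@H](O)[C@H]2OC4)cc1` gives 3990 nM in this test. Compound 2 `O=C1C=C(Nc2cccc(F)c2)C(=O)c2c1nc1n2[C@H]2OC[C@@H](O)[C@H]2OC1` gives 6440 nM and compound 3 `COc1ccc(NC2=CC(=O)c3nc4n(c3C2=O)[C@H]2OC[C@@H](O)[C@H]2OC4)cc1` gives 4780 nM under the same conditions. Compound 3 sits within the scatter of both compound 1 and compound 2, so these three numbers cannot be ranked.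

The next compound is compound 4 `Cc1ccc(NC2=CC(=O)c3nc4n(c3C2=O)[C@H]2OC[C@@H](O)[C@H]2OC4)cc1C`, which carries 3,4-dimethylphenyl in place of 4-methoxyphenyl on an amine nitrogen. For the measured compounds named here, no measured compound carries this group, so the closest guide is what other swaps at that nitrogen have done. Exchanging the ethyl of compound 1 for methoxy gave a small step (a 1.2-fold higher number from compound 1 to compound 3 (0.08 log units; within the scatter)). Moving from compound 1 to the 3-fluorophenyl group of compound 2 also gave a small step (a 1.6-fold higher number from compound 1 to compound 2 (0.21 log units; within the scatter)), as did the swap back to a 4-methoxyphenyl group (a 1.3-fold lower number from compound 2 to compound 3 (0.13 log units; within the scatter)). All three stayed within the scatter, so no step beyond the scatter is expected in this assay for this change. The estimated step is small and without a clear direction (a 1.0-fold higher number from compound 3 to compound 4 (0.00 log units; within the scatter)). Compound 4 is expected at 4800 nM (2400 nM to 9500 nM).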

Compound 4, half-maximal inhibitory concentration: 2690 nM
Beside the measured number, compound 4's estimate is 1.8-fold (0.25 log units) above it; the measured number falls inside the stated range.
By their numbers in this assay, from the lowest: compounds 4, 1, 3 and 2 (each within the scatter of the next, the first and the last beyond it).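

The swap of 3-fluorophenyl for 3,4-dimethylphenyl on the amine nitrogen gives a 2.4-fold lower number from compound 2 to compound 4 (0.38 log units; beyond the scatter) in this assay, and this is the first step among these compounds to pass the usual scatter, showing that the aryl group at this position can shift the number, though only modestly. The two other new steps, a 1.8-fold lower number from compound 3 to compound 4 (0.25 log units; within the scatter) and a 1.5-fold lower number from compound 1 to compound 4 (0.17 log units; within the scatter), both stay within the scatter, so 3,4-dimethylphenyl cannot be told apart from 4-methoxyphenyl or 4-ethylphenyl here, even though the all-carbon group enters in place of one containing oxygen in the first of these swaps. For the compounds shown here, nothing in the available data explains why only the step from 3-fluorophenyl passes the scatter.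

The compounds shown leave open whether 3-methylphenyl or 4-methylphenyl alone would match 3,4-dimethylphenyl, which would indicate whether both methyl groups are needed for the step from compound 2. Going by these compounds, all four compounds also carry a substituted phenyl ring on the nitrogen, so it remains open how a cyclohexyl group, a plain alkyl chain, or a phenyl ring bearing a carboxylic acid or an amine would read in this test.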